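Solubility notes: methylphenyl in place of benzimidazolyl

The compounds below may be only part of what the source reports. "The series", "measured", "known", "first", "only" and "open" are said of these compounds alone.

Measured compounds:
compound 1 `CNC(=O)c1cc(C(=O)NC2CC2)cn(Cc2ccc3nc[nH]c3c2)c1=O` — >= 163 ug/mL
compound 2 `CNC(=O)c1cc(C(=O)NCCO)cn(Cc2ccccc2)c1=O` — >= 140 ug/mL

In a physicochemical assay for solubility (a lower number here means a less soluble compound, a higher number a more soluble compound), compound 1 gives >= 163 ug/mL, which is a limit of the assay and not a number. In this assay compound 2 gives >= 140 ug/mL, likewise a limit. Compound 1 therefore stands only at the limit of >= 163 ug/mL in this assay, at which 1 of the 2 values shown sits, while the other value shown sits at the limit of >= 140 ug/mL in this assay, at which 1 of the 2 values shown sits; the two values show no order between them. Going by the values given here, no step between measured compounds that differ in a single place is available, so the size of any one change in this assay across this series is unknown.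

Compound 3 `CNC(=O)c1cc(C(=O)NC2CC2)cn(Cc2cccc(C)c2)c1=O` is not yet measured in this assay. It differs from compound 1 in one place: 3-methylphenyl in place of 1H-benzimidazol-6-yl on a saturated chain carbon bound to an aromatic nitrogen. With both shown values at limits, a step of modest size in the downward direction is expected for this assay, from compound 1 to compound 3, though a result again at the limit cannot be excluded; the expected step is an at least 1.8-fold lower number from compound 1 to compound 3 (0.25 log units; that floor lies within the scatter). Compound 3 is expected to give about 90 ug/mL, within a range of 30 ug/mL to 170 ug/mL.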

Compound 3, solubility: >= 205 ug/mL
Compound 3: a limit, no number; the forecaster's own chance of this, stated with the estimate: 35%; at least 2.2-fold (0.35 log units) between middle value and limit.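

In this assay compound 3 gives >= 205 ug/mL, a limit of the assay and not a number. Compound 1 gives >= 163 ug/mL, also a limit. With both values at limits, the step between compound 1 and compound 3 cannot be read. The compounds shown leave open whether, and by how much, 3-methylphenyl and 1H-benzimidazol-6-yl differ in this assay.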